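Lipophilicity notes: loss of one aryl chlorine

A few compounds are considered here, and "the series" means these few. Any claim that something is new, unique, unknown or untested is made for them only; others in the source may bear on it.

Three members of this series have been run in a physicochemical assay for lipophilicity, read by HPLC, at pH 7.4; a higher number here means a more lipophilic compound, a lower number a more polar compound. Compound 1 `O=C(O)COc1c(Cl)cc([C@H]2CC[C@]3(CC2)OOC2(O3)C3CC4CC(C3)CC2C4)cc1Cl` gives 3.3, the top figure of the three, though compound 2 `CC(C)(Oc1ccc([C@H]2CC[C@]3(CC2)OOC2(O3)C3CC4CC(C3)CC2C4)cc1)C(=O)O` gives 3.1, a value within the usual scatter of that of compound 1. Compound 3 `O=C(O)COc1ccc([C@H]2CC[C@]3(CC2)OOC2(O3)C3CC4CC2CC(C3)C4O)cc1` gives 1.7, well below compound 1 and clearly beyond the scatter. Among the measured compounds shown here, no two of the measured compounds differ in only one place, so no single measured step is available to anchor the next change.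

Compound 4 `O=C(O)COc1ccc([C@H]2CC[C@]3(CC2)OOC2(O3)C3CC4CC(C3)CC2C4)cc1Cl` has not yet been measured. It differs from compound 1 as follows: hydrogen in place of chloro on an aromatic carbon. With hydrogen in place of chloro on an aromatic carbon, a downward step of moderate size is expected, beyond the scatter but well short of the distance separating compound 1 from compound 3. The expected step is a number 0.60 log units lower from compound 1 to compound 4 (beyond the scatter). Compound 4 is accordingly estimated to give 2.7 in this assay, with a range from 2.3 to 3.1.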

Compound 4, distribution coefficient: 3.2
Beside the measured number, compound 4's estimate is 0.50 log units below it; the measured number lies above the stated range.
By their numbers in this assay, from the lowest: compound 3; then compounds 2, 4 and 1 (each within the scatter of the next).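

This gives the series its first single-place step: at the position ortho to a carboxymethoxy group and meta to a chloro group, hydrogen in place of chloro on an aromatic carbon gives a number 0.10 log units lower from compound 1 to compound 4 (within the scatter) in this assay. For this pair, therefore, the read-out does not distinguish chloro from hydrogen at this position, although this single step says nothing about other positions or other members of the series. Nothing at hand offers an explanation for this result.

The compounds shown leave open whether hydrogen in place of the remaining chloro group would read the same way, and whether a methoxy group, a nitrile or an amine at this position would give a step beyond the scatter. Equally open, on these data alone, is what a hydroxyl on the core of compound 4 would do on its own.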